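The source may hold more compounds than are shown below. What is called first, only, known or untested is meant among the compounds shown, and "the series" means these compounds.

In an ADME assay on Huh-7 cells (Homo sapiens) for cytotoxicity (a lower number here means that less compound is tolerated, a higher number that more compound is tolerated), compound 3 `O=C(NC(=S)N1CCc2c(OCCCCCOc3ccc(Cl)cc3)cccc21)c1cccs1` gives 10700 nM, the highest of the two plain numbers shown. Compound 2 `O=C(NC(=S)N1CCc2c(OCCCCCOc3ccc(Cl)cc3)cccc21)c1ccco1` gives 4620 nM, so that a 2.3-fold higher number from compound 2 to compound 3 (0.36 log units; beyond the scatter) is a modest step. Compound 1 `CCCC(=O)NC(=S)N1CCc2c(OCCCCCOc3ccc(Cl)cc3)cccc21` sits at a limit of the assay, > 50000 nM. Compound 4 `S=C(NC(=S)N1CCc2c(OCCCCCOc3ccc(Cl)cc3)cccc21)Oc1ccccc1` differs from compound 3 in one place: a group of 9 heavy atoms (7 carbon, 1 oxygen, 1 sulfur; one six-membered aromatic ring of carbon only) in place of a group of 7 heavy atoms (5 carbon, 1 oxygen, 1 sulfur; one five-membered aromatic ring with 1 hetero atom), on an amide-type nitrogen. The measured steps all change the group on this nitrogen: an at least 10-fold lower number from compound 1 to compound 2 (1.03 log units; beyond the scatter) and an at least 4.6-fold lower number from compound 1 to compound 3 (0.66 log units; beyond the scatter) each start from a limit and are large or at least modest, while a 2.3-fold higher number from compound 2 to compound 3 (0.36 log units; beyond the scatter) is modest. Swapping one aromatic group for another is therefore expected to move the number only a little, and the estimated step is a 1.1-fold higher number from compound 3 to compound 4 (0.05 log units; within the scatter). Compound 4 is expected to give about 12000 nM, between 4000 nM and 40000 nM.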

Compound 4, half-maximal cytotoxic concentration: > 50000 nM
Compound 4: only a limit was reported; the forecaster's own chance of this, stated with the estimate: 20%; middle value at least 4.1-fold (0.61 log units) away from the limit.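

Having an aromatic ring on this amide-type nitrogen does not by itself bring the number down: the group with a six-membered aromatic ring of carbon only gives an at least 4.6-fold higher number from compound 3 to compound 4 (0.66 log units; beyond the scatter) and an at least 10-fold higher number from compound 2 to compound 4 (1.03 log units; beyond the scatter). Earlier, only the five-membered aromatic rings of compound 2 and compound 3 had been seen here. The step between compound 1 and compound 4 cannot be read, since both values are limits: the limit of > 50000 nM in this assay, at which 2 of the 4 values shown sit.

The entering group changes both the ring and the atoms linking it, and the compounds shown do not separate these two changes. On these data alone, whether an amine or a longer chain on this nitrogen would also reach the limit stays open.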